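The source may hold more compounds than are shown below. What is called first, only, known or untested is meant among the compounds shown, and "the series" means these compounds.

Among the measured compounds shown here, compound 1 `CCOC(=O)/C=C/C(=O)N(CC(N)=O)NC(=O)[C@@H]1CCCN1C(=O)C1(NC(C)=O)CC1` is the weaker of the two compounds measured so far in an assay on isolated protein for inhibition of legumain (Mus musculus), read by fluorescence, with stated times of 30 s and 2.5 h; on this read-out lower numbers stand for stronger inhibition and higher numbers for weaker inhibition: compound 1 gives 9.3 nM, while compound 2 `CCOC(=O)C1OC1C(=O)N(CC(N)=O)NC(=O)[C@@H]1CCCN1C(=O)C1(NC(C)=O)CC1` gives 4.4 nM, and the step of a 2.1-fold lower number from compound 1 to compound 2 (0.33 log units; beyond the scatter) concerns a different part of the structure. Compound 3 `CCOC(=O)/C=C/C(=O)N(CC(N)=O)NC(=O)[C@@H]1CCCN1C(=O)c1cccc(NC(C)=O)c1` differs from compound 1 by 3-acetamidophenyl in place of 1-acetamidocyclopropyl on a carbonyl carbon. No measured step touches this position, so nothing shown bears directly on it. Compound 3 is therefore expected to stay close to compound 1, with an estimated step of a 1.1-fold higher number from compound 1 to compound 3 (0.03 log units; within the scatter) and an estimated value of 10 nM (range 3 nM to 35 nM).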

Compound 3, half-maximal inhibitory concentration: > 1000 nM
Compound 3: no number, only a limit; the forecaster's own chance of this, stated with the estimate: 5%; middle value at least 100-fold (2.00 log units) away from the limit.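

In this assay, among the compounds shown here, exchanging 1-acetamidocyclopropyl for 3-acetamidophenyl on this carbonyl carbon gives an at least 100-fold higher number from compound 1 to compound 3 (2.03 log units; beyond the scatter) and so shows that this position, which no earlier step touched, does not accept every group carrying an acetamide. The figure for compound 3 is a limit of the assay and not a number: the limit of > 1000 nM in this assay, at which 1 of the 3 values shown sits.

The compounds shown leave open whether a plain phenyl or a cyclohexyl group would fare as poorly here, or whether 1-aminocyclopropyl would keep the strength of compound 1. They also leave open whether the same exchange on compound 2 would cost as much.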